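This account rests on a few compounds, and the source may have more. Where it says the series, first, only, none or still open, it means among the compounds named here.

Compound 1 `O=S(=O)(Nc1ccc2oc(-c3ccccc3)nc2c1)c1ccc(Cl)c(Cl)c1` carries a 3,4-dichlorophenyl on the sulfonyl sulfur. In an assay on cells for inhibition of HSP60/HSP10 (Homo sapiens), with a stated time of 60 min (on this read-out higher numbers stand for weaker inhibition and lower numbers for stronger inhibition), compound 1 gives > 100000 nM, which is a limit of the assay and not a number. Compound 2 `O=S(=O)(Nc1ccc2oc(-c3ccccc3)nc2c1)c1ccc(Cl)c(C(F)(F)F)c1` differs from compound 1 by trifluoromethyl in place of chloro on an aromatic carbon. In this assay compound 2 gives > 100000 nM, again a limit. Compound 3 `C=Cc1ccc(S(=O)(=O)Nc2ccc(-c3nc4ccccc4o3)cc2)cc1` likewise gives > 100000 nM in this assay, a limit. For the measured compounds named here, the one step between measured compounds, a step that the two limits leave unreadable from compound 1 to compound 2, cannot be read because of the limit of > 100000 nM in this assay, at which 3 of the 3 values shown sit. Compound 4 `CS(=O)(=O)Nc1ccc2oc(-c3ccccc3)nc2c1` is the unmeasured member; its change from compound 1 is methyl in place of 3,4-dichlorophenyl on a sulfonyl sulfur. Going by the values given here, no measured step bears on this change, since the single measured step is unreadable and all three values sit at the limit. The step that the limit leaves unreadable from compound 1 to compound 4 is therefore expected to leave compound 4 where the rest of the series stands. Compound 4 is estimated at 150000 nM, with a range from 40000 nM to 500000 nM, and most probably the assay will again report only a limit.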

Compound 4, half-maximal inhibitory concentration: > 100000 nM
Compound 4: only a limit was reported; the forecaster's own chance of this, stated with the estimate: 85%; the middle value is on the limit's open side.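

No new step can be read from compound 1 to compound 4, because each value is a limit and not a number: the limit of > 100000 nM in this assay, at which 4 of the 4 values shown sit.

The compounds shown leave open whether any change on the sulfonyl sulfur gives a measurable value in this assay.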